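The compounds below may be only part of what the source reports. "The series", "measured", "known", "first", "only" and "open" are said of these compounds alone.

Among the measured compounds shown here, compound 2, `CCc1cccc2c(OC)c(-c3occ(C)c3COCC(F)(F)F)ccc12`, is the only member of the series with a number rather than a limit: in a functional assay on SK-BR-3 cells (Homo sapiens) for cytotoxicity, read by MTT assay, with a stated time of 72 h (a higher number here means that more compound is needed for the effect, a lower number that less compound is needed), compound 2 gives 5.3 ug/mL. For the measured compounds named here, its one measured neighbour is compound 1, `CCc1cccc2c(OC)c(-c3occ(C)c3CBr)ccc12`. In this assay compound 1 reaches only a limit, > 10 ug/mL. Going by the values given here, the single measured step is therefore an at least 1.8-fold lower number from compound 1 to compound 2 (0.27 log units; that floor lies within the scatter), and its floor rests on (the limit of > 10 ug/mL in this assay, at which 1 of the 2 values shown sits). Compound 3, `CCc1cccc2c(OC)c(-c3occ(C)c3COC(=O)CCN(CC)CC)ccc12`, departs from compound 2 by (2-(diethylamino)ethyl)carbonyl in place of 2,2,2-trifluoroethyl on an oxygen on a saturated carbon. No measured step touches this oxygen-bound group; the only step shown swaps the bromo for the 2,2,2-trifluoroethoxy and reaches no further than a floor that sits within the scatter. Among the compounds with values here, the step from compound 2 to compound 3 thus has no precedent, and an outcome beyond the scatter in either direction is not supported by anything measured. For compound 3 in this assay the expected step is a 1.1-fold lower number from compound 2 to compound 3 (0.03 log units; within the scatter). The expected value for compound 3 is 5 ug/mL, with a range from 2 ug/mL to 12 ug/mL, and a report of a limit only cannot be excluded.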

Compound 3, concentration for half-maximal effect: > 10 ug/mL
Compound 3: no number, only a limit; the forecaster's own chance of this, stated with the estimate: 25%; at least 2.0-fold (0.30 log units) between middle value and limit.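

Among the compounds shown here, at the oxygen on the saturated carbon, the first measured change to the group gives an at least 1.8-fold higher number from compound 2 to compound 3 (0.27 log units; that floor lies within the scatter), so replacing 2,2,2-trifluoroethyl with (2-(diethylamino)ethyl)carbonyl shows no gain here, though the floor of that step does not establish a loss. In this assay compound 3 gives > 10 ug/mL, which is a limit of the assay and not a number. The comparison of compound 1 with compound 3 cannot be read, and compound 2 remains the only compound with a number, so any reading of this position is bounded by the limit: the limit of > 10 ug/mL in this assay, at which 2 of the 3 values shown sit.

The compounds shown do not separate the carbonyl from the diethylamino end of the entering group, and they do not show how far compound 3 really lies from compound 2. A free hydroxyl, an acetyl group, or a diethylaminoethyl chain joined through the ether oxygen without a carbonyl would each bear on this, provided the value falls inside the measurable range of the assay.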